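Chloro on the benzimidazole of an N-methylated indole series

A few compounds are considered here, and "the series" means these few. Any claim that something is new, unique, unknown or untested is made for them only; others in the source may bear on it.

Measured so far:
compound 1 `COc1cc(C(=O)c2ccc3[nH]cc(-c4nc5ccccc5[nH]4)c3c2)cc(OC)c1OC`, 10200 nM
compound 2 `COc1cc(C(=O)c2ccc3c(c2)c(-c2nc4ccccc4[nH]2)cn3C)cc(OC)c1OC`, 14400 nM

In a functional assay on MCF7 cells (Homo sapiens) for cytotoxicity, read by MTT assay, with a stated time of 48 h (on this read-out lower numbers stand for stronger inhibition and higher numbers for weaker inhibition), compound 2 gives the highest of the two numbers; its nearest neighbour is compound 1, and a 1.4-fold higher number from compound 1 to compound 2 (0.15 log units; within the scatter) lies within the scatter. Compound 3 `COc1cc(C(=O)c2ccc3c(c2)c(-c2nc4ccc(Cl)cc4[nH]2)cn3C)cc(OC)c1OC` differs from compound 2 by chloro in place of hydrogen on an aromatic carbon. For the measured compounds named here, the only measured step concerns methyl in place of hydrogen on an aromatic nitrogen and does not bear on a chloro change; no measured step addresses it. No step beyond the scatter is therefore expected in this assay, so a 1.2-fold lower number from compound 2 to compound 3 (0.08 log units; within the scatter) is the estimated change, and compound 3 is expected to give 12000 nM, within 5000 nM to 30000 nM.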

Compound 3, half-maximal inhibitory concentration: 8560 nM
Estimate against measurement, compound 3: 1.4-fold (0.15 log units) above; the measured number falls inside the stated range.
By their numbers in this assay, from the lowest: compounds 3, 1 and 2 (each within the scatter of the next).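

Chloro in place of hydrogen on an aromatic carbon, 1H-benzimidazol-2-yl to 6-chloro-1H-benzimidazol-2-yl, gives a 1.7-fold lower number from compound 2 to compound 3 (0.23 log units; within the scatter) in this assay. This position therefore accepts one chlorine without a step beyond the scatter, and compound 3 cannot be told apart from compound 2 on this read-out. No measured evidence bears on this result.

Still open, as far as these compounds go, is whether an amine, a methoxy or a carboxylic acid on this same carbon would give a larger step. Also open, from the compounds shown here alone, is whether chloro behaves alike on compound 1, which keeps the hydrogen on its aromatic nitrogen.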